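Swapping the Aryl Group on the Sulfonyl Sulfur

The source may report more compounds than this note shows. Statements on the series, on what has been measured and on what is new or still open speak of the compounds shown alone.

Compound 2 `Cc1ccc2ncc(S(=O)(=O)c3ccc(F)cc3)c(N3CCC(C)CC3)c2c1` and compound 1 `COc1ccc(S(=O)(=O)c2cnc3ccc(C)cc3c2N2CCC(C)CC2)cc1Cl` share one core and differ only in 3-chloro-4-methoxyphenyl in place of 4-fluorophenyl on a sulfonyl sulfur. In an assay on isolated protein for displacement of a labelled ligand from metabotropic glutamate receptor 5 (Homo sapiens), with a stated time of 60 min, tested at 1 uM (on this read-out lower numbers stand for less inhibition and higher numbers for more inhibition at the one concentration tested (going by the name of the read-out)), compound 2 gives 90% and compound 1 gives 93%, a change of a number 3 percentage points higher from compound 2 to compound 1 (within the scatter). Compound 3 `COc1ccc2ncc(S(=O)(=O)c3ccc(F)cc3)c(N3CCC(C)CC3)c2c1` differs from compound 2 by methoxy in place of methyl on an aromatic carbon; in this assay compound 3 gives 27%, which is a number 63 percentage points lower from compound 2 to compound 3 (beyond the scatter). Compound 4 `COc1ccc2ncc(S(=O)(=O)c3ccc(OC)c(Cl)c3)c(N3CCC(C)CC3)c2c1` has not been measured; it differs from compound 3 by 3-chloro-4-methoxyphenyl in place of 4-fluorophenyl on a sulfonyl sulfur, the same change that turned compound 2 into compound 1, at the same place. Because a number 3 percentage points higher from compound 2 to compound 1 (within the scatter) hardly moved the read-out, the step expected for compound 4 is a number 3 percentage points higher from compound 3 to compound 4 (within the scatter). In this assay compound 4 is therefore expected to give 30%, within a likely range from 10% to 55%.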

Compound 4, a percentage reported as inhibition, at one concentration (the size of the read-out at that concentration, not a potency): 21%
Compound 4: middle estimate off by 9 percentage points, on the high side; the measured number falls inside the stated range.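

In this assay the swap of 4-fluorophenyl for 3-chloro-4-methoxyphenyl on the sulfonyl sulfur behaves alike on both cores, giving a number 6 percentage points lower from compound 3 to compound 4 (within the scatter) here and matching the earlier step: the same change on two cores in this assay, a number 3 percentage points higher (within the scatter) from compound 2 to compound 1 and a number 6 percentage points lower (within the scatter) from compound 3 to compound 4, 9 percentage points apart, within the scatter of two such steps. The change from methyl to methoxy on an aromatic carbon carries over as well, giving a number 72 percentage points lower from compound 1 to compound 4 (beyond the scatter), a large step much like the first one: the same change on two cores in this assay, a number 63 percentage points lower (beyond the scatter) from compound 2 to compound 3 and a number 72 percentage points lower (beyond the scatter) from compound 1 to compound 4, 9 percentage points apart, within the scatter of two such steps. This shows that the two changes act about the same way across these four compounds, but it does not show that they would on any other core, nor why methoxy lowers the number.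

Still open, on these data alone, is how other groups on that aromatic carbon, such as ethyl or chlorine, would read. Also open, as far as these compounds go, is what an amine or a carboxylic acid on the sulfonyl aryl group would do.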